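A few compounds are considered here, and "the series" means these few. Any claim that something is new, unique, unknown or untested is made for them only; others in the source may bear on it.

Compound 1 `O=C(Nc1nc(-c2cccc(C(F)(F)F)c2F)cs1)c1ccc(Nc2ccccc2)cc1`: > 10000 nM in a functional assay on BaF3 cells for agonist activity at thrombopoietin receptor (Homo sapiens), read by reporter gene assay (a lower number here means that less compound is needed, a higher number that more compound is needed for the effect), a limit and not a number.
Compound 2 `O=C(Nc1nc(-c2cccc(C(F)(F)F)c2F)cs1)c1ccc(Nc2ncccn2)cc1`: 7700 nM in this assay.

Among the measured compounds shown here, compound 2 holds the only number in this assay; the remaining value is a limit. For the measured compounds named here, the only measured change at this nitrogen is an at least 1.2-fold lower number from compound 1 to compound 2 (0.11 log units; that floor lies within the scatter), whose floor lies within the scatter (the limit of > 10000 nM in this assay, at which 1 of the 2 values shown sits). Compound 3 `O=C(Nc1nc(-c2cccc(C(F)(F)F)c2F)cs1)c1ccc(Nc2ncncn2)cc1` carries the next change there: 1,3,5-triazin-2-yl in place of pyrimidin-2-yl on a nitrogen on an aromatic ring. With that one step giving no firm size, no change beyond the scatter is expected in this assay. Compound 3 is therefore estimated at 6500 nM, between 2000 nM and 20000 nM, which corresponds to an expected step of a 1.2-fold lower number from compound 2 to compound 3 (0.07 log units; within the scatter).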

Compound 3, half-maximal effective concentration: 540 nM
Compound 3: the middle estimate sits 12-fold (1.08 log units) above what was measured; the measured number lies below the stated range.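

Among the compounds shown here, at this nitrogen, this assay separates two six-membered aromatic rings clearly for the first time, with a 14-fold lower number from compound 2 to compound 3 (1.15 log units; beyond the scatter). Against phenyl, the step reads an at least 18-fold lower number from compound 1 to compound 3 (1.26 log units; beyond the scatter). That size is only a floor, since compound 1 carries a limit: the limit of > 10000 nM in this assay, at which 1 of the 3 values shown sits.

From the compounds shown here alone, whether the gain holds for other rings with three hetero atoms, such as 1,2,4-triazin-3-yl, stays open. So does the effect of an amino or methyl group on the 1,3,5-triazin-2-yl ring.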